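Hydroxymethyl analogue in a weakly active lipoxygenase series

The source may hold more compounds than are shown below. What is called first, only, known or untested is meant among the compounds shown, and "the series" means these compounds.

Measured compounds:
compound 1 `Cc1ccc(S(=O)(=O)Oc2c(-c3ccccc3)c(-c3ccccc3)n3ccc(C#N)cc23)cc1`: 25000 nM
compound 2 `COc1ccc(C(O)c2c(-c3ccccc3)c(-c3ccccc3)n3ccc(C#N)cc23)cc1`: "not determined" (no result reported)
compound 3 `N#Cc1ccn2c(-c3ccccc3)c(-c3ccccc3)c(C(O)c3ccc(Cl)cc3)c2c1`: "not determined" (no result reported)

Within the data shown here, in an assay for inhibition of Polyunsaturated fatty acid lipoxygenase ALOX15 (Oryctolagus cuniculus) (on this read-out lower numbers stand for stronger inhibition and higher numbers for weaker inhibition), compound 1 gives 25000 nM, the only number in the set and a weak one. Compound 2 has no result in this assay, reported as "not determined" (no result reported). Compound 3 likewise shows "not determined" (no result reported) in this assay; it therefore stands without a single number, and one further entry in the series is in the same position. Compound 4 `N#Cc1ccn2c(-c3ccccc3)c(-c3ccccc3)c(CO)c2c1` has still to be measured in this assay.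

The change from compound 3 to compound 4 is hydrogen in place of 4-chlorophenyl on a saturated chain carbon bound to an aromatic carbon and an oxygen on a saturated carbon. Among the measured compounds shown here, no step between two measured compounds exists, so the size of this step in this assay cannot be read from the data. Nothing in the series indicates a shift beyond the scatter in either direction, and the only anchor is the weak result of compound 1. Compound 4 is therefore expected to remain at the weak end, because compound 1 gives 25000 nM and the shared core carries no sign of strong inhibition. Compound 4 is estimated at 30000 nM in this assay, with a range from 8000 nM to 100000 nM; a limit rather than a number is a real possibility.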

Compound 4, half-maximal inhibitory concentration: 34000 nM
The estimate for compound 4 lay 1.1-fold (0.05 log units) below the measured number, and the stated range covers the measured number.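

In this assay, among these compounds, the first readable step at this aromatic carbon is a 1.4-fold higher number from compound 1 to compound 4 (0.13 log units; within the scatter), and it lies within the scatter: hydroxymethyl in place of ((4-methylphenyl)sulfonyl)oxy leaves the series at the weak level, although the two groups differ considerably in structure. Compound 2 and compound 3 carry no number, and the steps that lead to them, including the exchange of 4-chlorophenyl for hydrogen on the saturated chain carbon, cannot be read. No measured information bears on why the read-out stays level across this exchange.

On these data alone, whether an aminomethyl group or a carboxylic acid on this aromatic carbon would move the number beyond the scatter remains open. Among the compounds shown here, also open is whether 4-chlorophenyl on the saturated chain carbon changes inhibition in either direction, and with only one readable step, the series gives no measure of how sensitive this position is to substitution.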